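Anilino swap at the core of the cinnamamide series

This account rests on a few compounds, and the source may have more. Where it says the series, first, only, none or still open, it means among the compounds named here.

Measured so far:
compound 1 `Cc1ccc(Nc2nc(Cl)nc3c2ncn3Cc2ccc(C(=O)Nc3ccccc3N)cc2)cc1`: 81.5%
compound 2 `CC1CCN(c2nc(Cl)nc3c2ncn3Cc2ccc(/C=C/C(=O)Nc3ccccc3N)cc2)CC1`: 26.9%
compound 3 `Cc1ccc(Nc2nc(Cl)nc3c2ncn3Cc2ccc(/C=C/C(=O)Nc3ccccc3N)cc2)cc1`: 15%

In a functional assay on HCT-116 cells (Homo sapiens) for antiproliferative activity, read by CCK-8 assay, with a stated time of 72 h, tested at 8 uM (a higher number here means a stronger effect of the compound at the concentration tested, a lower number a weaker effect), compound 3 gives the lowest of the three numbers. The nearest is compound 2, which shows 26.9%; the furthest is compound 1, which shows 81.5%. The step of a number 66.5 percentage points lower from compound 1 to compound 3 (beyond the scatter) is the large one in this set, and a number 11.9 percentage points lower from compound 2 to compound 3 (beyond the scatter) is modest.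

Compound 4 `Nc1ccccc1NC(=O)/C=C/c1ccc(Cn2cnc3c(Nc4cccc(Cl)c4)nc(Cl)nc32)cc1` is not yet measured. It differs from compound 3 only at the nitrogen on the core: 3-chlorophenyl in place of 4-methylphenyl on a nitrogen on an aromatic ring.

Of the measured steps, only a number 11.9 percentage points lower from compound 2 to compound 3 (beyond the scatter) touches the same nitrogen, and there the group entering was (4-methylphenyl)amino in place of 4-methylpiperidin-1-yl, not a swap between two aryl groups. Among the measured compounds shown here, no step exchanges one phenyl substituent pattern for another, so there is no direct guide. The two compounds carrying the 2-((2-aminophenyl)carbamoyl)ethenyl group, compound 2 and compound 3, both sit low, which suggests the cinnamamide part holds the value down regardless of the group on the nitrogen.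

The expected step of a number 5 percentage points higher from compound 3 to compound 4 (within the scatter) is therefore small, likely within the scatter, with no firm direction. For compound 4 the estimate in this assay is 20%, in a range from 5% to 45%.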

Compound 4, a percentage reported as inhibition, at one concentration (the size of the read-out at that concentration, not a potency): 15.8%
Beside the measured number, compound 4's estimate is 4.2 percentage points above it, and the stated range covers the measured number.
By their numbers in this assay, from the lowest: compounds 3 and 4 (each within the scatter of the next); then compound 2; then compound 1.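

In this assay, among the compounds shown here, replacing 4-methylphenyl with 3-chlorophenyl on the nitrogen gives a number 0.8 percentage points higher from compound 3 to compound 4 (within the scatter) as the first exchange of one aryl group for another at this position, so these two groups cannot be told apart in the cinnamamide series at this concentration. The comparison with the 4-methylpiperidin-1-yl group now rests on two aryl amines rather than one: a number 11.1 percentage points lower from compound 2 to compound 4 (beyond the scatter) runs the same way as a number 11.9 percentage points lower from compound 2 to compound 3 (beyond the scatter) and is of similar size, so in these compounds the gap follows the change from the piperidine to an aryl amine and not the particular substituent on the phenyl. Nothing available bears on what lies behind these numbers.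

As far as these compounds go, it remains open whether 3-chlorophenyl would behave the same way with the shorter (2-aminophenyl)carbamoyl group of compound 1, which gives 81.5% in this assay with 4-methylphenyl on the nitrogen. Also open, from the compounds shown here alone, is whether a methoxy group or a carboxylic acid on the phenyl, or a morpholine in place of the aryl amine, would lift the cinnamamide compounds from their present level.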